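Chloro-to-methoxy swap on the oxindole-side ring of compound 1

The source may hold more compounds than are shown below. What is called first, only, known or untested is meant among the compounds shown, and "the series" means these compounds.

Measured so far:
compound 1 `COc1cc2c(/C=C3/C(=O)Nc4ccc(Cl)cc43)c(Cl)n(Cc3cc(OC)c(OC)c(OC)c3)c2cc1C` gives 2190 nM in a functional assay on cells (Cancer cell lines, Homo sapiens) for cytotoxicity, with a stated time of 48 h; a higher number here means a weaker inhibitor of growth, a lower number a stronger inhibitor of growth
compound 2 `COc1cc2c(/C=C3/C(=O)Nc4cccc(Cl)c43)c(Cl)n(Cc3cc(OC)c(OC)c(OC)c3)c2cc1C` gives 2880 nM in this assay

Among the measured compounds shown here, compound 1 holds the lowest of the two numbers so far, though the step from it to compound 2, a 1.3-fold higher number from compound 1 to compound 2 (0.12 log units; within the scatter), stays within the scatter. Compound 3 `COc1ccc2c(c1)/C(=C\c1c(Cl)n(Cc3cc(OC)c(OC)c(OC)c3)c3cc(C)c(OC)cc13)C(=O)N2` differs from compound 1 by methoxy in place of chloro on an aromatic carbon. For the measured compounds named here, no measured step tests a chloro-to-methoxy exchange; the only step available, a 1.3-fold higher number from compound 1 to compound 2 (0.12 log units; within the scatter), moves the chloro and does not shift the number. The step to compound 3 in this assay is therefore expected to be small, with no clear direction. For compound 3 the expected step is a 1.2-fold higher number from compound 1 to compound 3 (0.07 log units; within the scatter), giving an estimate of 2600 nM with a range of 900 nM to 7500 nM.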

Compound 3, concentration for 50% growth inhibition: 11000 nM
For compound 3 the middle estimate is 4.2-fold (0.63 log units) below the measured one; measured number above the stated range.
By their numbers in this assay, from the lowest: compounds 1 and 2 (each within the scatter of the next); then compound 3.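

Among the compounds shown here, on this aromatic carbon the group itself matters: in this assay, methoxy in place of chloro gives a 5.0-fold higher number from compound 1 to compound 3 (0.70 log units; beyond the scatter), whereas the only earlier step, a 1.3-fold higher number from compound 1 to compound 2 (0.12 log units; within the scatter), moved the chloro without a change beyond the scatter. The series therefore tolerates the chloro at either place shown, but not this exchange. Nothing measured on these compounds accounts for the step.

Still open, on these data alone, is whether the higher number is specific to methoxy. As far as these compounds go, a methyl or an amine on the same carbon would test this, and whether methoxy behaves alike at the other chloro place also remains unknown.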